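The source may hold more compounds than are shown below. What is called first, only, known or untested is meant among the compounds shown, and "the series" means these compounds.

Measured compounds:
- compound 1 `Cc1ccc(CN2c3ccccc3C(OCc3ccccc3)=NS2(=O)=O)cc1`: 63000 nM
- compound 2 `N#Cc1ccc(CN2c3ccccc3C(=O)N(Cc3ccccc3)S2(=O)=O)cc1`: 62000 nM
- compound 3 `O=S1(=O)N=C(OCc2ccc(Cl)c(Cl)c2)c2ccccc2N1Cc1ccc(Cl)c(Cl)c1`: 48000 nM

These three compounds were tested in a functional assay on MRC5 cells (Homo sapiens); on this read-out higher numbers stand for lower toxicity in this test and lower numbers for higher toxicity in this test. Compound 1 gives 63000 nM, compound 2 gives 62000 nM and compound 3 gives 48000 nM. Among the compounds with values here, the three numbers sit close together: the gap from compound 2 to compound 1 and the gap from compound 2 to compound 3 both lie within the usual scatter of this assay, so no compound can be told apart from the others on this read-out. Compound 2 therefore stands in the middle of a group of values that, for practical purposes, look alike.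

Compound 4 `O=C1c2ccccc2N(Cc2ccccc2Cl)S(=O)(=O)N1Cc1ccccc1` has not yet been measured in this assay. Its difference from compound 2 is a single exchange: 2-chlorophenyl in place of 4-cyanophenyl on a saturated chain carbon bound to a sulfonamide nitrogen in a ring. Everything else in the molecule is kept.

Within the data shown here, no pair of measured compounds shows this particular exchange, so there is no measured step to lean on. What the three measured compounds do show is that rather different benzyl groups on this core all end up with values inside the scatter of one another. On that basis the step is expected to be small, no larger than the scatter, and with no clear direction; the expected step is a 1.1-fold lower number from compound 2 to compound 4 (0.05 log units; within the scatter). Compound 4 is thus estimated at 55000 nM in this assay, with a plausible range from 25000 nM to 120000 nM.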

Compound 4, half-maximal cytotoxic concentration: 60000 nM
Compound 4: the middle estimate sits 1.1-fold (0.04 log units) below what was measured; low and high end bracket the measured number.
By their numbers in this assay, from the lowest: compounds 3, 4, 2 and 1 (each within the scatter of the next).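

In this assay, placing 2-chlorophenyl where 4-cyanophenyl stood, on a saturated chain carbon bound to a sulfonamide nitrogen in a ring, gives a 1.0-fold lower number from compound 2 to compound 4 (0.01 log units; within the scatter). Within the data shown here, this is the first comparison in which only one place differs, so the earlier impression of a tolerant position now rests on a direct comparison, although for this single exchange only: losing the nitrile and gaining a chlorine leaves the read-out within the scatter, and the two group names also differ in where the substituent stands, so these differences cannot be separated here. No measured evidence is available to explain why the values stay so close.

The compounds shown leave open whether this place would stay just as undemanding with a different kind of group, such as an amine or a carboxylic acid on the phenyl ring, or a longer chain in place of the single saturated carbon. They also leave open how a plain phenyl with no substituent at this place would compare, which would show what the chlorine and the nitrile each contribute.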